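Amide-side aryl swap in a bis-benzylic sulfonamide series

The source may report more compounds than this note shows. Statements on the series, on what has been measured and on what is new or still open speak of the compounds shown alone.

Working notes on three measured compounds and one open one. In an assay on MDA-MB-231 cells for displacement of a labelled ligand from C-X-C chemokine receptor type 4 (Homo sapiens), read by fluorescence and microscopy, with stated times of 10 min and 30 min (on this read-out lower numbers stand for an effect already at smaller amounts and higher numbers for an effect only at larger amounts of compound), compound 1 `Cc1ccccc1C(=O)NCc1ccc(CNS(=O)(=O)c2ccccc2C)cc1` gives 10 nM and compound 2 `Cc1cccc(S(=O)(=O)NCc2ccc(CNC(=O)c3cccnc3)cc2)c1` gives 10 nM, the two being level at the digits printed and together the lowest of the three numbers. Within the data shown here, compound 3 `O=C(NCc1ccc(CNS(=O)(=O)c2ccc([N+](=O)[O-])cc2)cc1)c1cccnc1` gives 100 nM in this assay, and the only single-point step so far, a 10-fold higher number from compound 2 to compound 3 (1.00 log units; beyond the scatter), concerns the group on the sulfonyl sulfur, not the carbonyl side.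

The next compound, compound 4 `Cc1cccc(S(=O)(=O)NCc2ccc(CNC(=O)c3ccccc3C)cc2)c1`, differs from compound 2 by 2-methylphenyl in place of pyridin-3-yl on a carbonyl carbon. Among the measured compounds shown here, no measured step touches the carbonyl carbon, so the step from compound 2 to compound 3 offers no direct guide, and its size cannot be carried over. What is available is compound 1, which also carries 2-methylphenyl on a carbonyl carbon and gives 10 nM in this assay, level with compound 2. On that basis the expectation for compound 4 is a step of no change at the digits printed from compound 2 to compound 4 (within the scatter), which is to say none beyond the scatter. Compound 4 is therefore estimated at 10 nM in this assay, with a range from 4 nM to 30 nM.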

Compound 4, effective concentration (reported as EC, without a stated level of effect): 1000 nM
The estimate for compound 4 lay 100-fold (2.00 log units) below the measured number; measured number above the stated range.
By their numbers in this assay, from the lowest: compounds 1 and 2 (each within the scatter of the next); then compound 3; then compound 4.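

In this assay the carbonyl side is now shown to matter: with 3-methylphenyl on the sulfonyl sulfur, placing 2-methylphenyl on the carbonyl carbon gives a 100-fold higher number from compound 2 to compound 4 (2.00 log units; beyond the scatter). That group does not set the number by itself, since keeping it on the carbonyl carbon and changing only the sulfonyl group, 3-methylphenyl in place of 2-methylphenyl, gives a 100-fold higher number from compound 1 to compound 4 (2.00 log units; beyond the scatter). Among compound 1, compound 2 and compound 4, then, what 2-methylphenyl on the carbonyl carbon does depends on the group on the sulfonyl sulfur, and two methylphenyl groups that differ only in the numbering of their names are not interchangeable there.

A plain phenyl on the carbonyl carbon would separate the loss of the pyridine nitrogen from the arrival of the methyl, and pyridin-3-yl on the carbonyl carbon paired with 2-methylphenyl on the sulfonyl sulfur would show whether the sulfonyl change has the same size with that partner. Nothing at hand accounts for the size of either step, and how the two sides of the molecule come to depend on each other stays unexplained.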